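This account rests on a few compounds, and the source may have more. Where it says the series, first, only, none or still open, it means among the compounds named here.

Values in an assay on isolated protein for inhibition of Rho-associated protein kinase 1 (Homo sapiens), tested at 30 uM (on this read-out lower numbers stand for less inhibition and higher numbers for more inhibition at the one concentration tested (going by the name of the read-out)), for the three measured compounds:

Compound 1, `c1ccc(Sc2ncnc3[nH]cnc23)cc1`: 33%
Compound 2, `Cn1cnc2c(Sc3ccccc3)ncnc21`: 6%
Compound 3, `Cn1c(Br)nc2c(Sc3ccccc3)ncnc21`: 0%

Among these three, compound 2 stands second highest in this assay: its nearest neighbour is compound 3, whose number is within the scatter of it, and the furthest is compound 1, whose number is beyond the scatter above it. The unmeasured compound 4, `c1ccc(Cn2cnc3c(Sc4ccccc4)ncnc32)cc1`, grows out of compound 2 by a single change: phenyl in place of hydrogen on a saturated chain carbon bound to an aromatic nitrogen. Among the measured compounds shown here, two measured steps bear on this. The step of a number 27 percentage points lower from compound 1 to compound 2 (beyond the scatter) shows that putting a methyl on the aromatic nitrogen of the shared core took most of the inhibition away. The step of a number 6 percentage points lower from compound 2 to compound 3 (within the scatter) shows that a further change on compound 2, a bromo on an aromatic carbon, did not move the number beyond the scatter. Compound 2 already sits low, and a reading cannot go much lower than it does, so the step to compound 4 is expected to be small. The step of a number 2 percentage points higher from compound 2 to compound 4 (within the scatter) is expected to stay within the scatter. Compound 4 is estimated at 8% in this assay, with a range from 0% to 25%.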

Compound 4, a percentage reported as inhibition, at one concentration (the size of the read-out at that concentration, not a potency): 1%
For compound 4 the middle estimate is 7 percentage points above the measured one; the measured number falls inside the stated range.
By their numbers in this assay, from the lowest: compounds 3, 4 and 2 (each within the scatter of the next); then compound 1.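

In this assay, lengthening the group on the aromatic nitrogen from methyl to benzyl adds a six-membered aromatic ring of carbon only, yet the result is a number 5 percentage points lower from compound 2 to compound 4 (within the scatter), so the two substituted compounds cannot be told apart and the larger group brings back none of the inhibition seen for compound 1. Measured directly against the unsubstituted parent, the benzyl group gives a number 32 percentage points lower from compound 1 to compound 4 (beyond the scatter), which shows that the low reading on this nitrogen is not confined to methyl: both groups shown here leave the number far under that of compound 1, which carries only hydrogen at this place. Nothing available here explains why substitution at this nitrogen goes with so little inhibition. With compound 2 and compound 4 both reading close to the bottom of the scale, this assay cannot rank methyl against benzyl, so any real difference between them stays hidden. As far as these compounds go, it also remains open whether a group of another kind on this nitrogen, such as a chain ending in an amine or a carboxylic acid, would read as low as these or recover some of the inhibition.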